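Swapping Chloro for Methyl on the Anilino Ring

A few compounds are considered here, and "the series" means these few. Any claim that something is new, unique, unknown or untested is made for them only; others in the source may bear on it.

Compound 1 `Cc1nc(Nc2ccc(Cl)cc2)sc1C(=O)/C=C/c1ccccc1` gives 24600 nM in a functional assay on PC-3 cells (Homo sapiens) for cytotoxicity, read by MTT assay; on this read-out higher numbers stand for weaker inhibition and lower numbers for stronger inhibition. Compound 2 `COc1cccc(/C=C/C(=O)c2sc(Nc3ccc(Cl)cc3)nc2C)c1` shows only a limit in this assay, > 25000 nM. Compound 3 `Cc1nc(Nc2ccc(Cl)cc2)sc1C(=O)/C=C/c1ccc(Cl)cc1` also shows only a limit, > 25000 nM. Compound 2 thus stands at the limit where two of the three values sit (the limit of > 25000 nM in this assay, at which 2 of the 3 values shown sit); its step from compound 1 is an at least 1.0-fold higher number from compound 1 to compound 2 (0.00 log units; that floor lies within the scatter), and an at least 1.0-fold higher number from compound 1 to compound 3 (0.00 log units; that floor lies within the scatter) is of the same kind, while a step that the two limits leave unreadable from compound 2 to compound 3. Compound 4 `COc1cccc(/C=C/C(=O)c2sc(Nc3ccc(C)cc3)nc2C)c1` differs from compound 2 in one place: methyl in place of chloro on an aromatic carbon. Within the data shown here, no measured step touches this ring; each measured step changes the other phenyl ring, and none rises beyond the scatter. For compound 4 the expectation is therefore no step beyond the scatter in this assay, a step that the limit leaves unreadable from compound 2 to compound 4, giving an estimated 30000 nM with a range from 12000 nM to 80000 nM, most likely again only a limit.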

Compound 4, half-maximal inhibitory concentration: > 25000 nM
Compound 4: no number, only a limit (the forecaster's own chance of this, stated with the estimate: 70%); the middle value is on the limit's open side.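

Among these compounds, compound 2 and compound 4 both show only a limit in this assay, so no step between them can be read. The compounds shown leave open whether methyl in place of chloro changes cytotoxicity at all.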